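Methyl for fluoro on a benzoxazole bearing an aminopiperazine acetamide

The source may hold more compounds than are shown below. What is called first, only, known or untested is meant among the compounds shown, and "the series" means these compounds.

Compound 1 `CN(C)CCCN1CCN(CC(=O)Nc2ccc(-c3nc4cc(F)ccc4o3)cc2)CC1`: 12200 nM
Compound 2 `Cc1ccc2oc(-c3ccc(NC(=O)CN4CCN(CCCN(C)C)CC4)cc3)nc2c1`: 10600 nM
Compound 3 `Cc1cc(-c2nc3cc(F)ccc3o2)ccc1NC(=O)CN1CCN(CCCN(C)C)CC1`: 12200 nM

Three compounds share an amide-linked piperazine carrying a dimethylaminopropyl chain and were tested in a functional assay on A549 cells (Homo sapiens) for cytotoxicity, read by MTT assay, with a stated time of 24 h; on this read-out lower numbers stand for stronger inhibition and higher numbers for weaker inhibition. Compound 1 gives 12200 nM in this assay, compound 2 gives 10600 nM, and compound 3 gives 12200 nM; all three lie within the scatter of one another.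

From compound 1 to compound 2 the change is methyl in place of fluoro on an aromatic carbon, and the step is a 1.2-fold lower number from compound 1 to compound 2 (0.06 log units; within the scatter). Compound 3 differs from compound 1 by methyl in place of hydrogen on an aromatic carbon, with no change at the digits printed from compound 1 to compound 3 (within the scatter).

Compound 4 `Cc1ccc2oc(-c3ccc(NC(=O)CN4CCN(CCCN(C)C)CC4)c(C)c3)nc2c1` carries the same change as compound 2, made on the core of compound 3: methyl in place of fluoro on an aromatic carbon. Since a 1.2-fold lower number from compound 1 to compound 2 (0.06 log units; within the scatter) stayed within the scatter, a step of similar size is expected from compound 3 to compound 4, a 1.2-fold lower number from compound 3 to compound 4 (0.07 log units; within the scatter). Compound 4 is therefore estimated at 10500 nM in this assay, between 5500 nM and 20000 nM.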

Compound 4, half-maximal inhibitory concentration: 15300 nM
Compound 4: the middle estimate sits 1.5-fold (0.16 log units) below what was measured, within the range that was stated.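

In this assay, 5-methyl-1,3-benzoxazol-2-yl in place of 5-fluoro-1,3-benzoxazol-2-yl gives a 1.3-fold higher number from compound 3 to compound 4 (0.10 log units; within the scatter), and this step agrees with the same change on the other core: the same change on two cores in this assay, a 1.2-fold lower number (0.06 log units; within the scatter) from compound 1 to compound 2 and a 1.3-fold higher number (0.10 log units; within the scatter) from compound 3 to compound 4, 1.4-fold (0.16 log units) apart, within the scatter of two such steps

Methyl in place of hydrogen gives a 1.4-fold higher number from compound 2 to compound 4 (0.16 log units; within the scatter), and this change also carries across the two cores: the same change on two cores in this assay, no change at the digits printed (within the scatter) from compound 1 to compound 3 and a 1.4-fold higher number (0.16 log units; within the scatter) from compound 2 to compound 4, 1.4-fold (0.16 log units) apart, within the scatter of two such steps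

This shows that, for these four compounds, both changes stay within the scatter on each core, but it does not establish a direction for either change or show that a larger effect would carry over in the same way.

The compounds shown leave open whether the benzoxazole position tolerates other groups, such as a methoxy or a nitrile, with equally small steps. They also leave open whether a longer chain or a primary amine in place of the dimethylaminopropyl chain would move the number beyond the scatter.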